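The compounds below may be only part of what the source reports. "The series", "measured", "known", "first", "only" and "open" are said of these compounds alone.

Measured so far in an ADME assay on HeLa cells (Homo sapiens) for cytotoxicity, read by sulforhodamine B assay, with a stated time of 48 h, tested at 10 uM; a lower number here means less inhibition, a higher number more inhibition at the concentration tested (going by the name of the read-out):
- compound 1, `CCCCCCCc1cn(C(c2ccccc2)c2cc3cc(Br)ccc3nc2OC)nn1`: 9.7%
- compound 2, `COc1nc2ccc(Br)cc2cc1C(c1ccccc1)n1cc(CCCO)nn1`: 11.3%

Compound 2 stands alongside compound 1 in this assay: the step of a number 1.6 percentage points higher from compound 1 to compound 2 (within the scatter) lies within the usual scatter of such measurements, so the two numbers cannot be told apart, and both report little inhibition at the concentration tested.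

Compound 3, `COc1nc2ccc(Br)cc2cc1C(c1ccccc1)n1cc(CO)nn1`, carries the change hydroxy in place of 2-hydroxyethyl on a saturated chain carbon bound to an aromatic carbon relative to compound 2. Going by the values given here, only one measured step bears on it, the one from compound 1 to compound 2, which also shortened and reworked the chain on the triazole ring and gave a number 1.6 percentage points higher from compound 1 to compound 2 (within the scatter), a change that did not rise above the scatter. Both measured compounds sit low in this assay, and the chain at this position has so far moved the read-out by nothing that can be distinguished from repeat-measurement noise. Compound 3 is therefore expected to give a step of a number 1.3 percentage points lower from compound 2 to compound 3 (within the scatter), that is, no change beyond the scatter. The value for compound 3 in this assay is estimated at 10%, with a range from 1% to 22%.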

Compound 3, a percentage reported as inhibition, at one concentration (the size of the read-out at that concentration, not a potency): 0.25%
Estimate against measurement, compound 3: 9.8 percentage points above; the whole stated range lies above it.
By their numbers in this assay, from the lowest: compounds 3, 1 and 2 (each within the scatter of the next, the first and the last beyond it).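

Going by these compounds alone, at this position, on a saturated chain carbon bound to an aromatic carbon, hydroxy in place of 2-hydroxyethyl gave in this assay the first step to pass the scatter, a number 11.1 percentage points lower from compound 2 to compound 3 (beyond the scatter), which shows that the chain on the triazole can shift this read-out, if only modestly. Hydroxy in place of hexyl at the same carbon gave a number 9.5 percentage points lower from compound 1 to compound 3 (within the scatter), so compound 1 cannot be told apart from compound 3 or from compound 2, and only the gap between the 3-hydroxypropyl and hydroxymethyl chains stands out, with no steady trend along the three compounds. Nothing in the material at hand offers an explanation for this step.

The compounds shown leave open how an amine or a carboxylic acid in place of the terminal hydroxy would read in this assay, and whether a 4-hydroxybutyl chain would follow the 3-hydroxypropyl chain of compound 2 or part from it. From the compounds shown here alone, they also share one core, so how far the read-out answers to changes outside this chain remains open.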